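A few compounds are considered here, and "the series" means these few. Any claim that something is new, unique, unknown or untested is made for them only; others in the source may bear on it.

Working notes on a small set of anilino-triazine and anilino-pyrimidine analogues bearing a (3-methylbut-2-en-1-yl)oxy group.

Compound 1 `COc1ncnc(Nc2ccc(Cl)c(OCC=C(C)C)c2)n1` gives 18000 nM in an ADME assay on MT2 cells (Homo sapiens) for cytotoxicity; a lower number here means that less compound is tolerated, a higher number that more compound is tolerated. Compound 2 `COc1ncnc(Nc2ccc(C#N)c(OCC=C(C)C)c2)n1` differs from compound 1 by cyano in place of chloro on an aromatic carbon; in this assay compound 2 gives 42000 nM, and the step of a 2.3-fold higher number from compound 1 to compound 2 (0.37 log units; beyond the scatter) is a modest rise in the tolerated concentration.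

Compound 3 `COc1ccnc(Nc2ccc(Cl)c(OCC=C(C)C)c2)n1` carries a different core; the difference between the core of compound 3 and the core of compound 1 is not broken down here. In this assay compound 3 gives 9000 nM, which sits within the scatter of the value of compound 1, while the value of compound 2 lies clearly higher than that of compound 3.

Compound 4 `COc1ccnc(Nc2ccc(C#N)c(OCC=C(C)C)c2)n1` is not yet measured. It differs from compound 3 by cyano in place of chloro on an aromatic carbon, the same change, at the same place, that turns compound 1 into compound 2. For compound 4 the step of a 2.2-fold higher number from compound 3 to compound 4 (0.35 log units; beyond the scatter) is expected to be of a size close to a 2.3-fold higher number from compound 1 to compound 2 (0.37 log units; beyond the scatter), resting only on that one earlier pair. Compound 4 is therefore estimated at 20000 nM in this assay, with a plausible span from 9000 nM to 45000 nM.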

Compound 4, half-maximal cytotoxic concentration: 230 nM
Compound 4: the middle estimate sits 87-fold (1.94 log units) above what was measured; the measured number lies below the stated range.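

In this assay, cyano in place of chloro on the core of compound 3 gives a 39-fold lower number from compound 3 to compound 4 (1.59 log units; beyond the scatter), a large fall where the same change on the core of compound 1 gave a modest rise. A step read on one core therefore cannot be carried to the other in this series, as the two steps differ in both direction and size: the same change on two cores in this assay, a 2.3-fold higher number (0.37 log units; beyond the scatter) from compound 1 to compound 2 and a 39-fold lower number (1.59 log units; beyond the scatter) from compound 3 to compound 4, 91-fold (1.96 log units) apart, beyond the scatter of two such steps

For the compounds shown here, this shows that the outcome of this one change depends on the core, but it rests on only two pairs in a single assay and does not show which feature of the core matters or why the two steps part.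

Going by these compounds, it remains open whether a group such as methyl, trifluoromethyl or an amine in place of chloro would follow compound 2 or compound 4 on each core. On these data alone, it also remains open whether the sharp fall at compound 4 persists when the (3-methylbut-2-en-1-yl)oxy group gives way to a shorter chain such as ethoxy.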